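Swapping the base on a weakly active lactone

A few compounds are considered here, and "the series" means these few. Any claim that something is new, unique, unknown or untested is made for them only; others in the source may bear on it.

Three compounds share a core that carries a short chain ending in a small aromatic heterocycle, and all three were tested in an ADME assay on WI-38 cells (Homo sapiens) for inhibition, read by MTT assay, with a stated time of 72 h; on this read-out lower numbers stand for stronger inhibition and higher numbers for weaker inhibition. Compound 1 `NC1(CCn2ncc(=O)[nH]c2=O)OC(=O)C(OCc2ccccc2)=C1OCc1ccccc1` gives only a limit in this assay, > 100000 nM, rather than a number. Compound 2 `NC1(CCn2ccc(=O)[nH]c2=O)OC(=O)C(OCc2ccccc2)=C1OCc1ccccc1` likewise reaches only the limit of > 100000 nM. Going by the values given here, compound 3 `Nc1ccn(CCC2(N)OC(=O)C(OCc3ccccc3)=C2OCc2ccccc2)c(=O)n1` is the one compound with a measured number, 88900 nM, which makes it the sole fixed point here; the steps of an at least 1.1-fold lower number from compound 1 to compound 3 (0.05 log units; that floor lies within the scatter) and an at least 1.1-fold lower number from compound 2 to compound 3 (0.05 log units; that floor lies within the scatter) are floors that stay within the scatter, and the step that the two limits leave unreadable from compound 1 to compound 2 runs between two limits and cannot be read. Two of the three values sit at the limit of > 100000 nM in this assay, at which 2 of the 3 values shown sit. Compound 4 `Cc1cn(CCC2(N)OC(=O)C(OCc3ccccc3)=C2OCc2ccccc2)c(=O)[nH]c1=O` differs from compound 3 by a group of 9 heavy atoms (5 carbon, 2 nitrogen, 2 oxygen; one six-membered aromatic ring with 2 hetero atoms) in place of a group of 8 heavy atoms (4 carbon, 3 nitrogen, 1 oxygen; one six-membered aromatic ring with 2 hetero atoms), on a saturated chain carbon, two bonds along the chain from a saturated ring carbon. No exchange of this heterocycle seen so far has produced a readable shift, so for the step of a 1.1-fold higher number from compound 3 to compound 4 (0.05 log units; within the scatter) the expectation is no change beyond the scatter, with a fair chance that only a limit is reported. Compound 4 is therefore estimated at 100000 nM, with a range from 40000 nM to 300000 nM.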

Compound 4, half-maximal inhibitory concentration: > 100000 nM
Compound 4: no number, only a limit; the forecaster's own chance of this, stated with the estimate: 60%; the middle value sits exactly at the limit.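

Methyl in place of hydrogen on an aromatic carbon, the change that links compound 2 to compound 4, leaves both compounds at the same limit in this assay, so a ring carrying this methyl now joins the unmethylated rings at this place on the chain. Going by these compounds alone, the only step with a readable floor is an at least 1.1-fold higher number from compound 3 to compound 4 (0.05 log units; that floor lies within the scatter), while the steps from compound 1 and from compound 2 to compound 4 cannot be read. The four heterocycles now show no readable difference, and the values gather at one end: the limit of > 100000 nM in this assay, at which 3 of the 4 values shown sit.

On these data alone, how far compounds 1, 2 and 4 lie past that limit remains unknown. As far as these compounds go, whether an amine or a carboxylic acid in place of the heterocycle, or a longer chain, would give a value clearly under the limit also stays open.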